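Removing One Fluorine From Two Related Hydrazone Cores

The source may hold more compounds than are shown below. What is called first, only, known or untested is meant among the compounds shown, and "the series" means these compounds.

Of the compounds shown here, three have been measured in a functional assay on KB cells (Homo sapiens) for inhibition, read by sulforhodamine B assay, with a stated time of 48 h, tested at 10 uM; a higher number here means more inhibition of growth at the concentration tested, a lower number less inhibition of growth. Compound 1 `O=C(N/N=C/c1ccccc1O)c1ccc(-c2ccc(F)cc2)o1` gives 53.9% in this assay. Compound 3 `O=C(N/N=C/c1ccccc1O)c1ccc(-c2ccc(F)cc2F)o1` shares the core of compound 1 and carries one more fluoro group; in this assay compound 3 gives 75.3%. Compound 2 `O=C(N/N=C/c1ccc(-c2ccc(F)cc2F)o1)c1ccccc1O` is made of the same atoms as compound 3, joined differently, so the two belong to different cores; the difference between the two cores is not broken down here. In this assay compound 2 gives 61.8%, which stands close to the number of compound 1 and further from that of compound 3.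

The change from compound 3 to compound 1 is hydrogen in place of fluoro on an aromatic carbon. This single change produced a number 21.4 percentage points lower from compound 3 to compound 1 (beyond the scatter).

Compound 4 `O=C(N/N=C/c1ccc(-c2ccc(F)cc2)o1)c1ccccc1O` has not yet been measured. It differs from compound 2 by hydrogen in place of fluoro on an aromatic carbon, the same change at the same kind of place, now carried out on the core of compound 2. Going by the values given here, only one measured example of this change exists, and whether the second core answers in the same way cannot be known from the numbers at hand. With that caution, compound 4 is expected to give about 43% in this assay, with a likely range from 28% to 58%, because the same change gave a number 21.4 percentage points lower from compound 3 to compound 1 (beyond the scatter). The step this estimate implies is a number 18.8 percentage points lower from compound 2 to compound 4 (beyond the scatter), slightly damped against the one measured case.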

Compound 4, percent growth inhibition at one concentration: 84.6%
Compound 4: middle estimate off by 41.6 percentage points, on the low side; measured number above the stated range.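

On the core of compound 2, the change from 2,4-difluorophenyl to 4-fluorophenyl gives, in this assay, a number 22.8 percentage points higher from compound 2 to compound 4 (beyond the scatter). Set beside the earlier pair, the same replacement of fluoro by hydrogen moves the number in opposite directions on the two cores: the same change on two cores in this assay, a number 21.4 percentage points lower (beyond the scatter) from compound 3 to compound 1 and a number 22.8 percentage points higher (beyond the scatter) from compound 2 to compound 4, 44.2 percentage points apart, beyond the scatter of two such steps. Going by these compounds alone, this shows that, in this series, neither the direction nor the size of the step seen on one core can be carried over to the other, although it does not show why the two cores answer differently, and with only one pair on each core it gives no rule for any other core.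

The compounds shown leave open whether this reversal belongs to fluoro and hydrogen alone or would also appear with a chloro, methyl or methoxy group at the same place on both cores. They also leave open how the two cores would compare across a range of concentrations, since each number here is a growth inhibition read at one concentration on one cell line, and a single reading of this kind does not describe the full behaviour of a compound.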